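Swapping a methoxyphenyl for a cyanophenyl in a cytotoxicity screen

The compounds below may be only part of what the source reports. "The series", "measured", "known", "first", "only" and "open" are said of these compounds alone.

Measured so far:
compound 1, `COc1cccc(-c2nc3c(c(C)nn3-c3ccccc3)c(-c3ccccc3O)c2C#N)c1`: > 23000 nM
compound 2, `CCc1ccc(-c2nc3c(c(C)nn3-c3ccccc3)c(-c3ccccc3Cl)c2C#N)cc1`: > 20000 nM

Both measured compounds have been run in an ADME assay on BJ cells (Homo sapiens) for cytotoxicity, with a stated time of 72 h; a higher number here means that more compound is needed for the effect, a lower number that less compound is needed. Compound 1 `COc1cccc(-c2nc3c(c(C)nn3-c3ccccc3)c(-c3ccccc3O)c2C#N)c1` gives > 23000 nM there, which is a limit of the assay and not a number. Compound 2 `CCc1ccc(-c2nc3c(c(C)nn3-c3ccccc3)c(-c3ccccc3Cl)c2C#N)cc1` gives > 20000 nM in this assay, likewise a limit rather than a measured value. Compound 1 therefore stands at one of the two reported limits, (the limit of > 23000 nM in this assay, at which 1 of the 2 values shown sits), and nothing in the data places it in order against compound 2, which sits at the limit of > 20000 nM in this assay, at which 1 of the 2 values shown sits. Within the data shown here, no pair of measured compounds differs in a single place, so no measured step is known.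

Compound 3 `Cc1nn(-c2ccccc2)c2nc(-c3ccc(C#N)cc3)c(C#N)c(-c3ccccc3O)c12` is the compound still to be tested. Its change from compound 1 is 4-cyanophenyl in place of 3-methoxyphenyl on an aromatic carbon. Because compound 1 gives only > 23000 nM, the account expects no step beyond the scatter, and the estimated step that the limit leaves unreadable from compound 1 to compound 3 is essentially none. Compound 3 is estimated to give about 25000 nM in this assay, with an expected range from 8000 nM to 60000 nM, most probably reported again as a limit.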

Compound 3, half-maximal effective concentration: > 20000 nM
Compound 3: no number, only a limit (the forecaster's own chance of this, stated with the estimate: 80%); the middle value does not contradict the limit.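

In this assay compound 3 gives > 20000 nM, a limit of the assay and not a number. Compound 1 also stands at a limit, so no step can be read between compound 1 and compound 3. The compounds shown leave open whether 4-cyanophenyl in place of 3-methoxyphenyl changes the read-out in this assay at all.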